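Alkyl variation at the chain carbon: compounds 3 and 4

This account rests on a few compounds, and the source may have more. Where it says the series, first, only, none or still open, it means among the compounds named here.

Compound 1 `COc1ccccc1Cc1cnc(CCc2ccc(-c3ccccc3C(=O)O)cc2)[nH]1`: 1720 nM
Compound 2 `CC(C)(C)c1cnc(CCc2ccc(-c3ccccc3C(=O)O)cc2)[nH]1`: 4330 nM
Compound 3 `CC(C)CCc1cnc(CCc2ccc(-c3ccccc3C(=O)O)cc2)[nH]1`: 119 nM

In an in vitro functional assay on cells for agonist activity at Bombesin receptor subtype-3 (Homo sapiens), read by luminescence and calcium flux (on this read-out lower numbers stand for an effect already at smaller amounts and higher numbers for an effect only at larger amounts of compound), compound 3 stands lowest of the three, with compound 1 nearest and compound 2 furthest. The steps of a 14-fold lower number from compound 1 to compound 3 (1.16 log units; beyond the scatter) and a 36-fold lower number from compound 2 to compound 3 (1.56 log units; beyond the scatter) were both large, and a 2.5-fold higher number from compound 1 to compound 2 (0.40 log units; beyond the scatter) modest. Compound 4 `O=C(O)c1ccccc1-c1ccc(CCc2ncc(CC3CCCC3)[nH]2)cc1` differs from compound 3 by cyclopentyl in place of isobutyl on a saturated chain carbon bound to an aromatic carbon. Among the compounds with values here, no measured step covers this exchange of one alkyl group for another; the large steps onto compound 3 came from removing the 2-methoxyphenyl or the tert-butyl, not from reshaping the alkyl. A small step, near the scatter, is therefore expected in this assay, with a 1.3-fold lower number from compound 3 to compound 4 (0.12 log units; within the scatter) as the estimated shift. Compound 4 is estimated at 90 nM, within 30 nM to 300 nM.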

Compound 4, half-maximal effective concentration: 133 nM
Compound 4: the middle estimate sits 1.5-fold (0.17 log units) below what was measured, within the range that was stated.
By their numbers in this assay, from the lowest: compounds 3 and 4 (each within the scatter of the next); then compound 1; then compound 2.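

In this assay the chain carbon takes a cyclopentyl as readily as an isobutyl, with a 1.1-fold higher number from compound 3 to compound 4 (0.05 log units; within the scatter), so a ring in this group and the extra carbon leave the number unchanged within the scatter. The advantage over the earlier groups carries over to the ring, with a 33-fold lower number from compound 2 to compound 4 (1.51 log units; beyond the scatter) and a 13-fold lower number from compound 1 to compound 4 (1.11 log units; beyond the scatter), so it is not confined to the open isopentyl chain. Nothing available explains this tolerance.

From the compounds shown here alone, it remains open whether a longer chain, such as n-hexyl, or a larger ring, such as cyclohexyl, keeps the number at this level. An amine or a hydroxyl on this alkyl group is equally untested in the compounds shown.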